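The source may hold more compounds than are shown below. What is called first, only, known or untested is meant among the compounds shown, and "the series" means these compounds.

Three compounds share one core. Compound 1 `FC(F)(F)c1ccc(CSc2nc(Nc3ccccc3)c3ccccc3n2)cc1` gives 20000 nM in a functional assay on PC-3 cells (Homo sapiens) for cytotoxicity, read by MTT assay, with a stated time of 72 h; a higher number here means a weaker inhibitor, a lower number a stronger inhibitor. Compound 2 `FC(F)(F)c1ccc(CSc2nc(Nc3ccccc3Cl)c3ccccc3n2)cc1` gives 20400 nM, and compound 3 `COc1ccccc1Nc1nc(SCc2ccc(C(F)(F)F)cc2)nc2ccccc12` gives 14100 nM; all three numbers lie within the usual scatter of one another, so compound 3 is set apart from neither of the others. Compound 4 `FC(F)(F)c1ccc(CSc2nc(Nc3cccc(Cl)c3)c3ccccc3n2)cc1` has not yet been measured. It differs from compound 3 by 3-chlorophenyl in place of 2-methoxyphenyl on a nitrogen on an aromatic ring. For the measured compounds named here, two measured steps bear on this change: a 1.0-fold higher number from compound 1 to compound 2 (0.01 log units; within the scatter) and a 1.4-fold lower number from compound 2 to compound 3 (0.16 log units; within the scatter), both within the scatter. Because a 1.4-fold lower number from compound 2 to compound 3 (0.16 log units; within the scatter) moved nothing beyond the scatter, the expected step is a 1.3-fold higher number from compound 3 to compound 4 (0.11 log units; within the scatter), meaning no shift beyond the scatter. Compound 4 is therefore estimated at 18000 nM, with a range from 9000 nM to 36000 nM.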

Compound 4, half-maximal inhibitory concentration: 13400 nM
For compound 4 the middle estimate is 1.3-fold (0.13 log units) above the measured one; low and high end bracket the measured number.
By their numbers in this assay, from the lowest: compounds 4, 3, 1 and 2 (each within the scatter of the next).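

In this assay, the result places a chloro group at a second site on the phenyl ring, and changing 2-chlorophenyl to 3-chlorophenyl gives a 1.5-fold lower number from compound 2 to compound 4 (0.18 log units; within the scatter), so this site does not separate the two chloro compounds. The other comparisons give a 1.5-fold lower number from compound 1 to compound 4 (0.17 log units; within the scatter) and a 1.1-fold lower number from compound 3 to compound 4 (0.02 log units; within the scatter), so neither the added chloro nor the exchange for 2-methoxyphenyl leaves the scatter. No measurement offered here accounts for these results. On these data alone, whether an amine or a carboxylic acid on this phenyl ring would shift the number beyond the scatter remains open.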